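Nitro removal on two cores: antiproliferative notes

The source may hold more compounds than are shown below. What is called first, only, known or untested is meant among the compounds shown, and "the series" means these compounds.

Measured compounds:
compound 1 `CCOc1ccc2nc(Cl)c(/C=N/NC(=O)c3cc4cc([N+](=O)[O-])ccc4oc3=O)cc2c1`: 10500 nM
compound 2 `CCOc1ccc2nc(Cl)c(/C=N/NC(=O)c3cc4ccccc4oc3=O)cc2c1`: 29900 nM
compound 3 `O=C(N/N=C/c1ccncc1)c1cc2cc([N+](=O)[O-])ccc2oc1=O`: 26100 nM

All three numbers come from a functional assay on PANC-1 cells (Homo sapiens) for antiproliferative activity, read by fluorescence and resazurin assay, with a stated time of 48 h; a higher number here means a weaker inhibitor, a lower number a stronger inhibitor. Compound 1 and compound 2 share one core; compound 2 carries the change (hydrogen in place of nitro on an aromatic carbon), and that single change gave a 2.8-fold higher number from compound 1 to compound 2 (0.45 log units; beyond the scatter). Compound 3 stands on a different core, and the difference between the two cores is not broken down here. In this assay compound 3 gives 26100 nM; compound 3 and compound 2 lie within the usual scatter of each other, while compound 1 lies beyond it from compound 3.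

Compound 4 `O=C(N/N=C/c1ccncc1)c1cc2ccccc2oc1=O` has not been measured. It differs from compound 3 by hydrogen in place of nitro on an aromatic carbon, the same change at the same place as on the other core. Compound 4 is expected to step a 2.8-fold higher number from compound 3 to compound 4 (0.45 log units; beyond the scatter). This expectation rests on the step of the same kind already measured, a 2.8-fold higher number from compound 1 to compound 2 (0.45 log units; beyond the scatter), applied to the value of compound 3, 26100 nM. Compound 4 is therefore estimated at 73000 nM, with a likely span from 30000 nM to 160000 nM.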

Compound 4, half-maximal inhibitory concentration: 9750 nM
Estimate against measurement, compound 4: 7.5-fold (0.87 log units) above, and the stated range ends above it.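

On the second core, hydrogen in place of nitro on an aromatic carbon gives a 2.7-fold lower number from compound 3 to compound 4 (0.43 log units; beyond the scatter) in this assay. Set beside the first core, the same change runs in the opposite direction, and the gap between the two steps is larger than repeat measurements would explain: the same change on two cores in this assay, a 2.8-fold higher number (0.45 log units; beyond the scatter) from compound 1 to compound 2 and a 2.7-fold lower number (0.43 log units; beyond the scatter) from compound 3 to compound 4, 7.6-fold (0.88 log units) apart, beyond the scatter of two such steps. The step therefore does not carry from one core to the other in this series, so a value for one core cannot be estimated from the step on the other; two matched pairs do not show which feature of the cores governs the direction, nor how the change would behave on a third core.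

On these data alone, it remains open whether an amine or a methoxy group at the same place would follow nitro or hydrogen on each core. It is also open which part of the difference between the two cores goes with the reversal, since no compound shown separates those parts.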